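A few compounds are considered here, and "the series" means these few. Any claim that something is new, unique, unknown or untested is made for them only; others in the source may bear on it.

Compounds measured: compound 1 `CC1SC(c2cccc(C(=O)NCCCCc3ccccc3)c2)N(c2ccc(C3CC3)cc2)C1=O` gives 10000 nM; compound 2 `O=C(NCCCCc1ccccc1)c1cccc(C2SCC(=O)N2c2cccc(-c3c[nH]nn3)c2)c1` gives 20000 nM; compound 3 `COc1ccccc1N1C(=O)C(C)SC1c1cccc(C(=O)NCCCCc2ccccc2)c1` gives 20000 nM, all in a physicochemical assay for solubility, read by turbidimetry, measured as kinetic solubility, at pH 6.8; on this read-out lower numbers stand for lower solubility and higher numbers for higher solubility.

Compound 2 stands level with compound 3 in this assay, and its gap to compound 1 lies within the scatter. Among the compounds with values here, the only measured step, a 2.0-fold higher number from compound 1 to compound 3 (0.30 log units; within the scatter), swaps the whole aryl group on the amide-type nitrogen and is itself within the scatter. Compound 4 `C#Cc1cccc(N2C(=O)CSC2c2cccc(C(=O)NCCCCc3ccccc3)c2)c1` differs from compound 2 by ethynyl in place of 1H-1,2,3-triazol-4-yl on an aromatic carbon. Within the data shown here, no measured step varies a substituent on that phenyl ring, so nothing bears on it directly. A step of a 2.0-fold lower number from compound 2 to compound 4 (0.30 log units; within the scatter) is expected, leaning on compound 1 at 10000 nM. Compound 4 is thus expected near 10000 nM, between 4000 nM and 25000 nM.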

Compound 4, solubility: 10000 nM
Compound 4: the middle estimate sits on the measured number at the digits printed, and the stated range covers the measured number.
By their numbers in this assay, from the lowest: compounds 1, 4, 2 and 3 (each within the scatter of the next).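

In this assay, within the data shown here, the exchange of 1H-1,2,3-triazol-4-yl for ethynyl gives a 2.0-fold lower number from compound 2 to compound 4 (0.30 log units; within the scatter), the first measured step that varies this place on the phenyl ring. A five-membered aromatic ring with a hydrogen-bond donor leaves and a smaller group with no ring and no donor enters, yet the two compounds cannot be told apart on this read-out. Nothing available explains this result. Open, from the compounds shown here alone, is whether a carboxylic acid or an amine at this place would give a step beyond the scatter.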